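Working notes on the amide substituent series

This account rests on a few compounds, and the source may have more. Where it says the series, first, only, none or still open, it means among the compounds named here.

Measured so far:
compound 1 `COc1ccc(-c2cccc(C(=O)NCCN(C)C)c2)cc1S(=O)(=O)Nc1cccc(NCCNC(=O)c2cccc(C)c2)c1`, 64%
compound 2 `COc1ccc(-c2cccc(C(=O)N(C)Cc3ccccc3)c2)cc1S(=O)(=O)Nc1cccc(NCCNC(=O)c2cccc(C)c2)c1`, 61%

In a functional assay on CHO-RD-HGA16 cells for agonist activity at Orexin receptor type 2 (Homo sapiens), read by fluorescence and calcium flux, with a stated time of 30 min (a higher number here means a larger maximal response, a lower number a smaller maximal response), compound 1 gives 64% and compound 2 gives 61%. Among the measured compounds shown here, compound 2 stands lowest of the two numbers, with compound 1 nearest, the one change of a number 3 percentage points lower from compound 1 to compound 2 (within the scatter) lying within the scatter.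

Compound 3 `COc1ccc(-c2cccc(C(=O)N(C)Cc3ccccn3)c2)cc1S(=O)(=O)Nc1cccc(NCCNC(=O)c2cccc(C)c2)c1` is not yet measured. Its change from compound 2 is pyridin-2-yl in place of phenyl on a saturated chain carbon bound to an amide-type nitrogen. For the measured compounds named here, no measured step touches this exchange; only the amide substituent step a number 3 percentage points lower from compound 1 to compound 2 (within the scatter) is relevant, and it was flat. Therefore no step beyond the scatter is expected, a number 1 percentage points lower from compound 2 to compound 3 (within the scatter). For compound 3 the estimate is 60%, range 45% to 75%.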

Compound 3, largest response reached (Emax), in percent of the reference or control that the assay uses: 76%
Compound 3: the middle estimate sits 16 percentage points below what was measured, outside the stated range (above it).
By their numbers in this assay, from the lowest: compounds 2 and 1 (each within the scatter of the next); then compound 3.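

In this assay, among the compounds shown here, this position responds to the ring itself: pyridin-2-yl in place of phenyl on a saturated chain carbon bound to an amide-type nitrogen gives a number 15 percentage points higher from compound 2 to compound 3 (beyond the scatter), the first step beyond the scatter. Methyl((pyridin-2-yl)methyl)amino in place of (2-(dimethylamino)ethyl)amino on a carbonyl carbon gives a number 12 percentage points higher from compound 1 to compound 3 (beyond the scatter), so compound 3 stands clear of both earlier compounds. Nothing available explains this step.

Open: whether pyridin-3-yl or pyridin-4-yl gives the same step, and whether pyrimidin-2-yl or a longer chain carrying the pyridin-2-yl ring changes it.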